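Three Limits and an Extended Amine on the Peroxide Core

The source may hold more compounds than are shown below. What is called first, only, known or untested is meant among the compounds shown, and "the series" means these compounds.

Compound 1 `NCCCCCOc1ccc([C@H]2CC[C@]3(CC2)OOC2(O3)C3CC4CC(C3)CC2C4)cc1` was run in an ADME assay on microsomes from liver (Homo sapiens) for metabolic stability, read by LC-MS, tested at 1 uM; on this read-out higher numbers stand for fast clearance and lower numbers for slow clearance. In this assay compound 1 gives < 7 mL.min-1.g-1, which is a limit of the assay and not a number. Compound 2 `NCCOCCOc1ccc([C@H]2CC[C@]3(CC2)OOC2(O3)C3CC4CC(C3)CC2C4)cc1` gives < 7 mL.min-1.g-1, also a limit. Compound 3 `NCCOc1ccc([C@H]2CC[C@]3(CC2)OOC2(O3)C3CC4CC(C3)CC2C4)cc1` gives < 7 mL.min-1.g-1, again a limit. The steps a step that the two limits leave unreadable from compound 1 to compound 2, a step that the two limits leave unreadable from compound 1 to compound 3 and a step that the two limits leave unreadable from compound 2 to compound 3 therefore have no readable size, as shown by the limit of < 7 mL.min-1.g-1 in this assay, at which 3 of the 3 values shown sit.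

Compound 4 `CC(C)(O)CNCCCOc1ccc([C@H]2CC[C@]3(CC2)OOC2(O3)C3CC4CC(C3)CC2C4)cc1` differs from compound 1 by (2-hydroxy-2-methylpropyl)amino in place of 2-aminoethyl on a saturated chain carbon, three bonds along the chain from an oxygen on an aromatic ring. No measured step can be read for size, so none points in a direction for this change. The expected step is a step that the limit leaves unreadable from compound 1 to compound 4, no larger than the scatter. Compound 4 is estimated to give 6 mL.min-1.g-1 in this assay, with a range from 3 mL.min-1.g-1 to 15 mL.min-1.g-1, and most likely reported once more as a limit.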

Compound 4, intrinsic clearance in microsomes: 8 mL.min-1.g-1
For compound 4 the middle estimate is 1.3-fold (0.12 log units) below the measured one, within the range that was stated.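

In this assay, going by these compounds alone, compound 4 is the first here to give a number and not a limit, so the change to (2-hydroxy-2-methylpropyl)amino on the chain now has a floor: an at least 1.1-fold higher number from compound 1 to compound 4 (0.05 log units; that floor lies within the scatter), an at least 1.1-fold higher number from compound 3 to compound 4 (0.05 log units; that floor lies within the scatter) and an at least 1.1-fold higher number from compound 2 to compound 4 (0.05 log units; that floor lies within the scatter). Each floor lies within the scatter, so no rise in clearance can be claimed for this change at this position. The steps among compounds 1, 2 and 3 still cannot be read, and most values still sit at one limit: the limit of < 7 mL.min-1.g-1 in this assay, at which 3 of the 4 values shown sit.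

As far as these compounds go, how far compounds 1, 2 and 3 lie under that limit stays open. So does whether a carboxylic acid or a tertiary amine at the chain end would give a step beyond the scatter.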